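The compounds below may be only part of what the source reports. "The series", "measured", "known", "first", "only" and "open" are said of these compounds alone.

Working notes on the urea series.

Compound 3 `COc1cc(Cl)cc(-c2nn(-c3cccc(NC(=O)Nc4ccc(Cl)c(Cl)c4)c3)cc2-c2ccncc2)c1` carries the shared core with a 3,4-dichlorophenyl group on the urea nitrogen. In a functional assay on A498 cells (Homo sapiens) for inhibition, read by sulforhodamine B assay, with a stated time of 48 h, tested at 1 uM (a higher number here means a weaker effect of the compound at the concentration tested, a lower number a stronger effect), compound 3 gives 73%. Among the three measured members this is the second highest number. For the measured compounds named here, its nearest neighbour is compound 1 `COc1cc(Cl)cc(-c2nn(-c3cccc(NC(=O)Nc4ccc(Cl)c(C(F)(F)F)c4)c3)cc2-c2ccncc2)c1`, which in this assay gives 78%; the only single-change step in the set, a number 5 percentage points lower from compound 1 to compound 3 (within the scatter), lies within the scatter. The furthest member is compound 2 `COc1cc(Cl)cc(-c2nn(-c3cccc(NC(=O)Nc4cc(C(F)(F)F)cc(C(F)(F)F)c4)c3)cc2-c2ccncc2)c1`, which in this assay gives 37%, a number beyond the scatter below compound 3.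

Compound 4 `COc1cc(Cl)cc(-c2nn(-c3cccc(NC(=O)Nc4cccc(C(F)(F)F)c4)c3)cc2-c2ccncc2)c1` is the next member: 3-(trifluoromethyl)phenyl in place of 3,4-dichlorophenyl on an amide-type nitrogen. Going by the values given here, the only measured step that bears on this exchange is a number 5 percentage points lower from compound 1 to compound 3 (within the scatter), a swap of chloro for trifluoromethyl at one aromatic carbon that moved the number by an amount within the scatter. Among the compounds with values here, compound 2, the member with two trifluoromethyl groups, shows the lowest number, but no single-change step connects it to compound 3 or compound 4, so its value is not taken as a guide. The expectation for compound 4 is therefore a step of a number 2 percentage points higher from compound 3 to compound 4 (within the scatter), none beyond the scatter. Compound 4 is estimated at 75%, with a range from 55% to 92%.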

Compound 4, a percentage reported as activity, at one concentration (the size of the read-out at that concentration, not a potency): 75%
The estimate for compound 4 equals the measured number at the digits printed; the range from low to high includes it.
By their numbers in this assay, from the lowest: compound 2; then compounds 3, 4 and 1 (each within the scatter of the next).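

In this assay, the exchange of 3,4-dichlorophenyl for 3-(trifluoromethyl)phenyl on the amide-type nitrogen gives a number 2 percentage points higher from compound 3 to compound 4 (within the scatter), and hydrogen in place of chloro gives a number 3 percentage points lower from compound 1 to compound 4 (within the scatter), so neither the chloro group of compound 1 nor the change from the dichloro pattern to a single trifluoromethyl registers here. For the compounds shown here, the one step that does register is hydrogen in place of trifluoromethyl, a number 38 percentage points higher from compound 2 to compound 4 (beyond the scatter): this first direct link to the member with two trifluoromethyl groups ties its lower number to that one extra group, a single-change comparison that the earlier compounds lacked. Nothing among the data accounts for the size of this step.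

On these data alone, it remains open whether the effect is specific to a second trifluoromethyl group or whether another group in its place, such as a nitrile or an amine, would give a similar read-out. As far as these compounds go, each number is a read-out at a single concentration in one cell line, so the size of the effect at other concentrations and any effect in other cell types also remain open.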